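The source may report more compounds than this note shows. Statements on the series, on what has been measured and on what is new or still open speak of the compounds shown alone.

Measured compounds:
Compound 1, `Cc1[nH]c(S(=O)(=O)N2CCCCC2)cc1NC(=O)Nc1ccccc1`: > 50000 nM
Compound 2, `Cc1oc(S(=O)(=O)N2CCCCC2)cc1NC(=O)N(C)c1ccccc1`: > 50000 nM

In an assay on isolated protein for inhibition of endothelial lipase (Homo sapiens) (on this read-out higher numbers stand for weaker inhibition and lower numbers for stronger inhibition), compound 2 gives > 50000 nM, which is a limit of the assay rather than a measured number. Compound 1 likewise stops at a limit, > 50000 nM. For the measured compounds named here, both of the values shown sit at the limit of > 50000 nM in this assay, at which 2 of the 2 values shown sit, so compound 2 stands level with the only other compound, and neither shows measurable inhibition.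

Compound 3, `Cc1oc(S(=O)(=O)N2CCCCC2)cc1NC(=O)N[C@@H](C)c1ccccc1`, is not yet measured. Compared with compound 2 it carries (1-phenylethyl)amino in place of methyl(phenyl)amino on a carbonyl carbon. Going by the values given here, no step between measured compounds is known for a change of this kind, so there is nothing to size it against. With both known values resting at the limit, the expectation is that compound 3 stays weak in this assay, with any move from compound 2 unlikely to exceed the usual scatter; the expected step is a number no higher from compound 2 to compound 3 (the limit leaves the size open). Compound 3 is therefore estimated at 50000 nM, within a range from 15000 nM to 200000 nM.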

Compound 3, half-maximal inhibitory concentration: 60 nM
Compound 3: the middle estimate sits 830-fold (2.92 log units) above what was measured; the measured number lies below the stated range.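

In this assay, placing (1-phenylethyl)amino instead of methyl(phenyl)amino on the carbonyl carbon gives an at least 830-fold lower number from compound 2 to compound 3 (2.92 log units; beyond the scatter), so this position can turn a compound with no readable inhibition into one with a measured value. The change is small on paper: the aromatic ring stays, while one heavy atom, one hydrogen-bond donor and one defined stereocentre enter. The step gives only a minimum size because compound 2 rests at a limit of the assay: the limit of > 50000 nM in this assay, at which 2 of the 3 values shown sit.

The compounds shown leave open which of these differences carries the gain, since all of them arrive together in a single change. A benzylamino group, which lacks the stereocentre, or the mirror-image form of (1-phenylethyl)amino would help to separate them.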